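Ester Replaces Aryl at the Saturated Ring Carbon

The source may hold more compounds than are shown below. What is called first, only, known or untested is meant among the compounds shown, and "the series" means these compounds.

Compound 3 `Cc1nn(-c2ncnc3nc[nH]c23)c2c1C(c1ccc(OC(C)C)cc1)CC(=O)N2` gives 2700 nM in a functional assay on HEK293 cells for agonist activity at G-protein coupled receptor 39 (Homo sapiens), read by scintillation proximity assay and inositol phosphate accumulation, with a stated time of 75 min; on this read-out lower numbers stand for an effect already at smaller amounts and higher numbers for an effect only at larger amounts of compound. Compound 1 `Cc1cc(C)n(CCOC2CC(=O)Nc3c2c(C)nn3-c2ncnc3nc[nH]c23)n1` gives 2000 nM in this assay, and compound 2 `Cc1nn(-c2ncnc3nc[nH]c23)c2c1C(OCc1ccc(C(C)C)cc1)CC(=O)N2` gives 1690 nM; none of the three numbers separates from the others beyond the scatter. Compound 4 `Cc1nn(-c2ncnc3nc[nH]c23)c2c1C(OC(=O)c1ccc(F)cc1)CC(=O)N2` carries ((4-fluorophenyl)carbonyl)oxy in place of 4-isopropoxyphenyl on a saturated ring carbon. Going by the values given here, two measured steps touch the same saturated ring carbon: a 1.2-fold lower number from compound 1 to compound 2 (0.07 log units; within the scatter) and a 1.4-fold higher number from compound 1 to compound 3 (0.13 log units; within the scatter), both within the scatter, so neither a change of the oxygen-linked group nor an exchange between an oxygen-linked and a carbon-linked group has moved the read-out. Compound 4 is therefore expected to show a 1.1-fold lower number from compound 3 to compound 4 (0.03 log units; within the scatter), nothing beyond the scatter. The expected number for compound 4 is 2500 nM, with a range from 800 nM to 8000 nM.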

Compound 4, half-maximal effective concentration: 245 nM
Beside the measured number, compound 4's estimate is 10-fold (1.01 log units) above it; measured number below the stated range.
By their numbers in this assay, from the lowest: compound 4; then compounds 2, 1 and 3 (each within the scatter of the next).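

At this saturated ring carbon the read-out does respond to the group it carries, though compounds 1, 2 and 3 had shown no difference beyond the scatter: the change gives an 11-fold lower number from compound 3 to compound 4 (1.04 log units; beyond the scatter), and the (4-fluorophenyl)carbonyl group on the oxygen gives a 6.9-fold lower number from compound 2 to compound 4 (0.84 log units; beyond the scatter) and an 8.2-fold lower number from compound 1 to compound 4 (0.91 log units; beyond the scatter). An oxygen on this carbon does not by itself go with the lower number, as compound 1 and compound 2 carry one too. Nothing available explains the gain.

Compound 4 alone carries the carbonyl and the fluorine, so their shares remain unseparated. On these data alone, whether an unsubstituted benzoyl group, or an amide nitrogen in place of the linking oxygen, would keep the lower number remains open.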